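From isobutyl to 4-fluorophenyl: what to expect for compound 4

A few compounds are considered here, and "the series" means these few. Any claim that something is new, unique, unknown or untested is made for them only; others in the source may bear on it.

In a physicochemical assay for solubility, at pH 7 (on this read-out lower numbers stand for lower solubility and higher numbers for higher solubility), compound 3 `CCN1CCC(C(=O)N2Cc3c(NC(=O)CC(C)C)n[nH]c3C2(C)C)CC1` reads > 225000 nM, which is a limit of the assay and not a number. Compound 4 `CCN1CCC(C(=O)N2Cc3c(NC(=O)c4ccc(F)cc4)n[nH]c3C2(C)C)CC1` differs from it in one place: 4-fluorophenyl in place of isobutyl on a carbonyl carbon. For the measured compounds named here, no measured step makes this swap directly. Compound 1 `CC(C)(C)C(=O)N1Cc2c(NC(=O)c3ccc(F)cc3)n[nH]c2C1(C)C` gives 235000 nM and compound 2 `CC(=O)N1CCC(C(=O)N2Cc3c(NC(=O)c4ccc(F)cc4)n[nH]c3C2(C)C)CC1` gives 204000 nM, and both already carry the 4-fluorophenyl. Going by the values given here, the only measured step is a 1.2-fold lower number from compound 1 to compound 2 (0.06 log units; within the scatter), with 1-acetylpiperidin-4-yl in place of tert-butyl on a carbonyl carbon. Since that step stayed small, and compound 2 holds 204000 nM, no change beyond the scatter is expected. The expected step is an at least 1.1-fold lower number from compound 3 to compound 4 (0.05 log units; that floor lies within the scatter). For compound 4 the estimate is 200000 nM, with an expected range from 110000 nM to 280000 nM.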

Compound 4, solubility: > 225000 nM
Compound 4: only a limit was reported; the forecaster's own chance of this, stated with the estimate: 35%; middle value at least 1.1-fold (0.05 log units) from the limit.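

In this assay compound 4 reads > 225000 nM, a limit and not a number, so 4-fluorophenyl in place of isobutyl on this carbonyl carbon leaves the reading at the limit that compound 3 also shows. Ethyl in place of acetyl on an amine nitrogen in a ring gives an at least 1.1-fold higher number from compound 2 to compound 4 (0.04 log units; that floor lies within the scatter). The steps to compound 4 from compound 3 and compound 1 cannot be read, and the size of the swap stays hidden because both compounds stop at the same limit: the limit of > 225000 nM in this assay, at which 2 of the 4 values shown sit.

From the compounds shown here alone, how far compound 3 and compound 4 lie past that limit stays open. So does whether a carboxylic acid or a longer chain on this carbonyl carbon would give a reading under the limit.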